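The compounds below may be only part of what the source reports. "The series", "measured", "known", "first", "only" and "open" are said of these compounds alone.

In an ADME assay on microsomes from liver (Homo sapiens) for metabolic stability, using NADPH, with a stated time of 40 min, tested at 2 uM (a lower number here means that the compound disappears faster, a higher number that the compound lasts longer), compound 3 `Cc1cccc2c(-c3ccc4ccccc4n3)c[nH]c12` stands lowest of the three measured compounds, at 0.35 h. Compound 1 `Cc1cccc2c(-c3ccc4cccc(F)c4n3)c[nH]c12` gives 0.983 h, and compound 2 `Cc1cccc2c(-c3ccc4cccc(Br)c4n3)c[nH]c12` gives 2.4 h. Compound 4 `Cc1cccc2c(-c3ccc4cccc(Cl)c4n3)c[nH]c12` has yet to be measured. It differs from compound 3 by chloro in place of hydrogen on an aromatic carbon. Going by the values given here, no chloro compound has a measured value here, so the expectation rests on the fluoro and bromo compounds, which carry their groups on that same aromatic carbon. Among the compounds with values here, two measured steps bear most directly on the change: a 2.8-fold lower number from compound 1 to compound 3 (0.45 log units; beyond the scatter) and a 6.9-fold lower number from compound 2 to compound 3 (0.84 log units; beyond the scatter). Both lie beyond the scatter, and both show that the compound with hydrogen has the lower number. Read in reverse, they point to a higher number when hydrogen is replaced. The step of a 2.4-fold higher number from compound 1 to compound 2 (0.39 log units; beyond the scatter) gives the gap between the fluoro and bromo compounds, and it too lies beyond the scatter. A rise of modest size, within the span of the two hydrogen steps, is therefore expected. The expected change is a 4.6-fold higher number from compound 3 to compound 4 (0.66 log units; beyond the scatter). For compound 4 the estimated half-life is 1.6 h, with an expected range from 0.9 h to 2.8 h.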

Compound 4, half-life: 1.75 h
Beside the measured number, compound 4's estimate is 1.1-fold (0.04 log units) below it; the range from low to high includes it.
By their numbers in this assay, from the lowest: compound 3; then compounds 1, 4 and 2 (each within the scatter of the next, the first and the last beyond it).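

With chloro on this aromatic carbon, this assay gives a 5.0-fold higher number from compound 3 to compound 4 (0.70 log units; beyond the scatter), so fluoro, chloro and bromo all now stand beyond the scatter from hydrogen at this one place, and the rise on leaving hydrogen is no longer shown by only two halogens. The chloro compound does not separate from either of its neighbours: the data give a 1.4-fold lower number from compound 2 to compound 4 (0.14 log units; within the scatter) and a 1.8-fold higher number from compound 1 to compound 4 (0.25 log units; within the scatter), both within the scatter, even though compound 1 and compound 2 lie beyond the scatter of each other, so the three halogens cannot be put into a clean order through compound 4. Nothing given here accounts for why the half-life follows these groups at this carbon.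

The compounds shown carry only halogens at this place, so they leave open whether a methyl, a methoxy, a nitrile or an amine on the same aromatic carbon would also lift the half-life above that of compound 3. They also leave open whether chloro would give a similar rise on any other carbon of the core.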